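A few compounds are considered here, and "the series" means these few. Any claim that something is new, unique, unknown or untested is made for them only; others in the source may bear on it.

Compound 1 `Cc1ccnc(NC(c2ccc3cccnc3c2O)c2c(F)cccc2Cl)c1`: > 40000 nM
Compound 2 `CCc1ccc(C(Nc2ccccn2)c2ccc3cccnc3c2O)cc1`: 170 nM
Compound 3 `Oc1c(C(Nc2ccccc2)c2ccccc2)ccc2cccnc12`: 110 nM

Of the compounds shown here, three sharing one core have been tested in an assay for inhibition of protein disulfide-isomerase (Homo sapiens), with a stated time of 1 h; on this read-out lower numbers stand for stronger inhibition and higher numbers for weaker inhibition. Compound 1 gives only a limit in this assay, > 40000 nM, so its true value is not known. That places compound 1 at the limit of > 40000 nM in this assay, at which 1 of the 3 values shown sits. Compound 2 gives 170 nM in this assay. Compound 3 gives 110 nM in this assay. The values of compound 2 and compound 3 lie within the usual scatter of each other, so nothing separates them.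

Compound 4 `Cc1ccnc(NC(c2ccc(F)cc2)c2ccc3cccnc3c2O)c1` has not yet been tested. It differs from compound 1 in one place: 4-fluorophenyl in place of 2-chloro-6-fluorophenyl on a saturated chain carbon bound to an aromatic carbon and a nitrogen on an aromatic ring. Compound 2 and compound 3 each carry a phenyl ring on that same saturated chain carbon, and each gives a measured number rather than a limit. In its build compound 4, with its 4-fluorophenyl, stands closer to those two than compound 1 does.

The step is therefore expected to be large and toward stronger inhibition, with an estimated at least 130-fold lower number from compound 1 to compound 4 (2.12 log units; beyond the scatter). Compound 4 is estimated to give 300 nM, expected to fall between 80 nM and 3000 nM.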

Compound 4, half-maximal inhibitory concentration: 140 nM
Beside the measured number, compound 4's estimate is 2.1-fold (0.33 log units) above it; the measured number falls inside the stated range.
By their numbers in this assay, from the lowest: compounds 3, 4 and 2 (each within the scatter of the next). At a limit, above all of these: compound 1.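

For the compounds shown here, this pair is the first in the set to differ in one place only, so in this assay the whole step of an at least 280-fold lower number from compound 1 to compound 4 (2.45 log units; beyond the scatter) belongs to the group on the saturated chain carbon. Exchanging 2-chloro-6-fluorophenyl for 4-fluorophenyl leaves the rest of the molecule untouched and takes away only one heavy atom, yet it turns a compound without a measured number into one with a measured number, so inhibition here depends strongly on which substituted phenyl ring sits at this position. The true size of the step remains unknown because compound 1 gives only a limit and not a number: the limit of > 40000 nM in this assay, at which 1 of the 4 values shown sits.

The change removes the chlorine and also replaces one fluorophenyl pattern with another, so this pair cannot show which of the two differences matters, or whether both are needed. The compounds shown also leave open whether this position accepts something other than a phenyl ring, such as a cyclohexyl group, or a phenyl ring carrying a carboxylic acid or an amine.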